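Replacing the alkyne linker with a directly bound phenyl

The source may hold more compounds than are shown below. What is called first, only, known or untested is meant among the compounds shown, and "the series" means these compounds.

Measured compounds:
compound 1, `Cn1cncc1C(OCc1ccc(C#N)cc1C#Cc1ccccn1)c1ccc(C#N)cc1`: > 0.1 nM
compound 2, `Cn1cncc1C(OCc1ccc(C#N)cc1C#CC(C)(C)C)c1ccc(C#N)cc1`: 76.9 nM
compound 3, `Cn1cncc1C(OCc1ccc(C#N)cc1C#Cc1ccccc1)c1ccc(C#N)cc1`: 0.1 nM

The three measured compounds share one core and differ only in the group on the triple-bonded carbon. In a functional assay on NIH3T3 cells (Mus musculus) (on this read-out lower numbers stand for an effect already at smaller amounts and higher numbers for an effect only at larger amounts of compound), compound 1 is known only by a limit, > 0.1 nM, so no number fixes where it stands (the limit of > 0.1 nM in this assay, at which 1 of the 3 values shown sits). Within the data shown here, compound 3 reaches the same figure as a measured number, while compound 2 sits far higher: the step of a 770-fold lower number from compound 2 to compound 3 (2.89 log units; beyond the scatter) is the one clearly readable change here, and it shows that an aromatic ring on the triple-bonded carbon matters greatly against a tert-butyl group. The steps a step that the limit leaves unreadable from compound 1 to compound 2 and a number no higher from compound 1 to compound 3 (the limit leaves the size open) are left open by the limit.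

Compound 4, `Cn1cncc1C(OCc1ccc(C#N)cc1-c1ccccc1)c1ccc(C#N)cc1`, takes a different route: phenyl in place of 2-(pyridin-2-yl)ethynyl on an aromatic carbon. Among the measured compounds shown here, no measured step removes the triple bond itself, so the change is only partly covered. An aromatic ring stays, but the spacer and its nitrogen leave; compound 1 is therefore expected to lose some ground, with the step that the limit leaves unreadable from compound 1 to compound 4 estimated in this assay. Compound 4 is estimated at 5 nM, with a range from 0.3 nM to 80 nM.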

Compound 4, half-maximal effective concentration: 140 nM
Compound 4: middle estimate off by 28-fold (1.45 log units), on the low side; measured number above the stated range.
By their numbers in this assay, from the lowest: compound 3; then compounds 2 and 4 (each within the scatter of the next).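

Among these compounds, removing the triple bond and setting phenyl directly on the aromatic carbon has a large cost in this assay, with a 1400-fold higher number from compound 3 to compound 4 (3.15 log units; beyond the scatter), so an aromatic ring at this position is not enough by itself, which the earlier compounds, all of which kept the triple bond, could not show. Set against the 3,3-dimethylbut-1-yn-1-yl group, directly bound phenyl gives a 1.8-fold higher number from compound 2 to compound 4 (0.26 log units; within the scatter), so these two groups cannot be told apart in this assay, and the advantage that phenyl held over tert-butyl on the triple-bonded carbon does not carry over once the triple bond is gone. Compound 1 remains known only as a limit, so its steps, including the one to compound 4, cannot be read: the limit of > 0.1 nM in this assay, at which 1 of the 4 values shown sits.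

The compounds shown leave open whether the triple bond could be replaced by another link, such as an ethylene chain or an amide, with the phenyl ring kept at its end. They also leave open how a directly bound pyridin-2-yl group, or a phenyl ring carrying an amine or a carboxylic acid, would compare with the directly bound phenyl of compound 4.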